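Indazole replacement at the pyrazolo-pyrimidine aryl position

The source may hold more compounds than are shown below. What is called first, only, known or untested is meant among the compounds shown, and "the series" means these compounds.

Working notes on three measured compounds in a functional assay on MCF7 cells (Homo sapiens) for inhibition, read by CCK-8 assay, with a stated time of 48 h (on this read-out lower numbers stand for stronger inhibition and higher numbers for weaker inhibition), and one that awaits measurement. Compound 1 `COc1ccc(-c2cc3nccc(-c4cc(OC)c(OC)c(OC)c4)n3n2)cc1N` gives 27 nM. Compound 2 `COc1cc(-c2ccnc3cc(-c4ccc(Cl)cc4)nn23)cc(OC)c1OC` gives 2320 nM. Compound 3 `COc1ccc(-c2cc3nccc(-c4cc(OC)c(OC)c(OC)c4)n3n2)cc1F` gives 183 nM, the second highest of the three numbers: it sits a 6.8-fold higher number from compound 1 to compound 3 (0.83 log units; beyond the scatter) and a 13-fold lower number from compound 2 to compound 3 (1.10 log units; beyond the scatter).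

Compound 4 `COc1cc(-c2ccnc3cc(-c4ccc5cnn(C)c5c4)nn23)cc(OC)c1OC` is formed from compound 3 by the change (1-methyl-1H-indazol-6-yl in place of 3-fluoro-4-methoxyphenyl on an aromatic carbon). For the measured compounds named here, the steps that bear on it are those that swap the aryl group on the same aromatic carbon of the shared core: an 86-fold higher number from compound 1 to compound 2 (1.93 log units; beyond the scatter), a 6.8-fold higher number from compound 1 to compound 3 (0.83 log units; beyond the scatter) and a 13-fold lower number from compound 2 to compound 3 (1.10 log units; beyond the scatter). These show that the aryl group at this place shifts the number by a large margin in either direction, with the methoxy-bearing aryl groups giving the lower numbers and the 4-chlorophenyl the highest. The 1-methyl-1H-indazol-6-yl carries no methoxy but brings a second acceptor in its five-membered ring; nothing measured here resembles it directly, so the direction is uncertain and the expected step is a 1.2-fold lower number from compound 3 to compound 4 (0.09 log units; within the scatter), within the scatter. Compound 4 is therefore estimated at 150 nM, with a range from 30 nM to 900 nM in this assay.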

Compound 4, half-maximal inhibitory concentration: 279 nM
Estimate against measurement, compound 4: 1.9-fold (0.27 log units) below; the range from low to high includes it.
By their numbers in this assay, from the lowest: compound 1; then compounds 3 and 4 (each within the scatter of the next); then compound 2.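

In this assay, the swap of 3-fluoro-4-methoxyphenyl for 1-methyl-1H-indazol-6-yl gives a 1.5-fold higher number from compound 3 to compound 4 (0.18 log units; within the scatter), so at this place, on an aromatic carbon next to the ring nitrogen, a group with no methoxy and a fused five-membered aromatic ring stands level with the fluoro compound. Against 4-chlorophenyl the same group gives an 8.3-fold lower number from compound 2 to compound 4 (0.92 log units; beyond the scatter), so among the four compounds the lower numbers are no longer confined to methoxy-bearing aryl groups, with compound 4 as the exception to that earlier reading. The amino-bearing aryl group keeps its lead over the new group, at a 10-fold higher number from compound 1 to compound 4 (1.01 log units; beyond the scatter), and compound 1 now stands beyond the scatter from all three others as the most potent of the set.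

No measurement here bears on what lies behind these steps. Still open, from the compounds shown here alone, is whether an amino group added to the 1-methyl-1H-indazol-6-yl would bring the number towards that of compound 1, and whether a hydroxyl in place of the amino group of compound 1, or an indazole carrying an ethyl instead of the methyl, would hold the number.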